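Swapping trifluoromethyl for cyano on a shared core

The source may report more compounds than this note shows. Statements on the series, on what has been measured and on what is new or still open speak of the compounds shown alone.

Compound 1 `CN1C/C(=C\c2ccc(C#N)cc2)C(=O)/C(=C/c2cccnc2)C1`: 13600 nM
Compound 2 `CN1C/C(=C\c2ccncc2)C(=O)/C(=C/c2ccccc2F)C1`: 7000 nM
Compound 3 `CN1C/C(=C\c2ccncc2)C(=O)/C(=C/c2ccc(C(F)(F)F)cc2)C1`: 17700 nM

In a functional assay on SMMC-7721 cells (Homo sapiens) for cytotoxicity, read by MTT assay, with a stated time of 24 h (on this read-out lower numbers stand for stronger inhibition and higher numbers for weaker inhibition), compound 3 gives 17700 nM. Compound 1, at 13600 nM, cannot be told apart from it within the scatter, so these two together form the upper end of the small set. Compound 2, at 7000 nM, lies lower than compound 3, and that gap is beyond the scatter.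

The next compound to be tested is compound 4 `CN1C/C(=C\c2ccncc2)C(=O)/C(=C/c2ccc(C#N)cc2)C1`. It differs from compound 3 in one place, with cyano in place of trifluoromethyl on an aromatic carbon, para to a large group (cyano in place of trifluoromethyl on an aromatic carbon).

Among the compounds with values here, no measured pair isolates this change, so the data offer no direct step for it. The nearest guide is compound 1, which also carries a cyano group and gives 13600 nM, although it differs from compound 4 elsewhere in the structure. On that basis, no step beyond the scatter is expected in this assay. The estimate is a 1.4-fold lower number from compound 3 to compound 4 (0.13 log units; within the scatter), a small expected shift towards a lower number. For compound 4 the expected value is 13000 nM, with an estimated range of 6000 nM to 27000 nM.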

Compound 4, half-maximal inhibitory concentration: 18500 nM
The estimate for compound 4 lay 1.4-fold (0.15 log units) below the measured number; low and high end bracket the measured number.
By their numbers in this assay, from the lowest: compounds 2, 1, 3 and 4 (each within the scatter of the next, the first and the last beyond it).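

In this assay, within the data shown here, the step of a 1.0-fold higher number from compound 3 to compound 4 (0.02 log units; within the scatter) is the first measured pair to isolate this change on an aromatic carbon, para to a large group, and it leaves cyano and trifluoromethyl indistinguishable at this position. Among these compounds, the step of a 1.4-fold higher number from compound 1 to compound 4 (0.13 log units; within the scatter) shows that, with the cyano group in place, pyridin-4-yl and pyridin-3-yl also cannot be told apart, whereas the modest step of a 2.6-fold higher number from compound 2 to compound 4 (0.42 log units; beyond the scatter), with 4-cyanophenyl in place of 2-fluorophenyl, lies beyond the scatter and is the only step here that does. Nothing available bears on what lies behind these steps.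

On these data alone, whether a methoxy group or an amine on the same aromatic carbon would also stay within the scatter of cyano and trifluoromethyl remains open. Also open, as far as these compounds go, is whether the step between compound 2 and compound 4 belongs to the fluorine, to its place on the ring, or to the loss of the cyano group, since that step replaces the whole aryl group at once.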